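Benzyl in place of butyl on the shared core

A few compounds are considered here, and "the series" means these few. Any claim that something is new, unique, unknown or untested is made for them only; others in the source may bear on it.

Measured compounds:
compound 1 `CCCC/N=C(\NC#N)Nc1cccnc1` — 20 mg/kg
compound 2 `CC(C)/N=C(\NC#N)Nc1cccnc1` — 2.5 mg/kg
compound 3 `N#CN/C(=N\C1CCCC1)Nc1cccnc1` — 20 mg/kg

In a functional assay on the whole organism (blood, strain Wistar-Okamoto) with Rattus norvegicus as the target, with a stated time of 5 days (on this read-out higher numbers stand for an effect only at larger amounts of compound and lower numbers for an effect already at smaller amounts), compound 1 gives 20 mg/kg and stands level with compound 3, the two together highest of the three numbers, while compound 2 lies furthest away. Compound 4 `N#CN/C(=N\Cc1ccccc1)Nc1cccnc1` differs from compound 1 by phenyl in place of propyl on a saturated chain carbon bound to a double-bonded nitrogen. Going by the values given here, two measured steps touch the same position: an 8.0-fold lower number from compound 1 to compound 2 (0.90 log units; beyond the scatter), and no change at the digits printed from compound 1 to compound 3 (within the scatter). Neither replaces a chain carbon with phenyl, so they bear only loosely; the cyclopentyl step shows that a larger group at this nitrogen need not move the number. For compound 4 a step of about no change at the digits printed from compound 1 to compound 4 (within the scatter) in this assay is expected, within the scatter. Compound 4 is estimated at 20 mg/kg, between 5 mg/kg and 80 mg/kg.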

Compound 4, minimum effective dose: 20 mg/kg
For compound 4 middle estimate and measured number coincide at the digits printed; measured number inside the range.
By their numbers in this assay, from the lowest: compound 2; then compounds 1, 3 and 4 (each within the scatter of the next).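

In this assay, phenyl in place of propyl on a saturated chain carbon bound to a double-bonded nitrogen gives no change at the digits printed from compound 1 to compound 4 (within the scatter). An aromatic ring can therefore enter at this position with the number staying level, as with the cyclopentyl of compound 3, while the isopropyl of compound 2, at 2.5 mg/kg, remains the lowest number of the four. Nothing shown gives a reason for this result.

Going by these compounds, whether a phenethyl group or a chlorophenyl group would also stay level remains open. So does whether tert-butyl would follow compound 2 or compound 1.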